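Sulfonyl group exchange in a bromophenyl enone series

A few compounds are considered here, and "the series" means these few. Any claim that something is new, unique, unknown or untested is made for them only; others in the source may bear on it.

Compound 1 `COc1ccccc1/C=C(\C(=O)c1ccc(Br)cc1)S(=O)(=O)Cc1ccc(F)cc1` gives 25000 nM in a functional assay on DU-145 cells (Homo sapiens) for inhibition, read by trypan blue exclusion, with a stated time of 96 h; on this read-out lower numbers stand for stronger inhibition of growth and higher numbers for weaker inhibition of growth. Compound 2 `O=C(/C(=C\c1ccc(Br)cc1)S(=O)(=O)c1ccc(Br)cc1)c1ccc(Br)cc1` gives 10000 nM. Compound 3 `Cc1ccc(S(=O)(=O)/C(=C/c2ccc(Br)cc2)C(=O)c2ccc(Br)cc2)cc1` gives 10000 nM.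

Compound 3 stands level with compound 2, the two together at the lowest numbers of the three; compound 1 gives a higher number, beyond the scatter. Among the measured compounds shown here, the only single-change step measured is no change at the digits printed from compound 2 to compound 3 (within the scatter), a methyl in place of bromo on an aromatic carbon. Compound 4 `O=C(/C(=C\c1ccc(Br)cc1)S(=O)(=O)Cc1ccc(F)cc1)c1ccc(Br)cc1` differs from compound 3 by 4-fluorobenzyl in place of 4-methylphenyl on a sulfonyl sulfur. For the measured compounds named here, no measured step changes the group on the sulfonyl sulfur alone; compound 1 also carries a 4-fluorobenzyl there but differs elsewhere as well, so its value is no clean guide. The expected step in this assay is therefore small, at most a modest move toward a higher number, a 1.5-fold higher number from compound 3 to compound 4 (0.18 log units; within the scatter). Compound 4 is estimated at 15000 nM, within 6000 nM to 40000 nM.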

Compound 4, concentration for 50% growth inhibition: 25000 nM
Compound 4: the middle estimate sits 1.7-fold (0.22 log units) below what was measured, within the range that was stated.
By their numbers in this assay, from the lowest: compounds 2 and 3 (each within the scatter of the next); then compounds 1 and 4 (each within the scatter of the next).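

In this assay the sulfonyl sulfur now shows a move: 4-fluorobenzyl in place of 4-methylphenyl gives a 2.5-fold higher number from compound 3 to compound 4 (0.40 log units; beyond the scatter) and 4-fluorobenzyl in place of 4-bromophenyl gives a 2.5-fold higher number from compound 2 to compound 4 (0.40 log units; beyond the scatter) at this same position. With 4-fluorobenzyl on the sulfur, 4-bromophenyl in place of 2-methoxyphenyl on the double-bonded chain carbon gives no change at the digits printed from compound 1 to compound 4 (within the scatter) so that exchange does not show in the number here.

Nothing at hand bears on the cause of these steps. As far as these compounds go, whether an amine or a longer chain on the sulfonyl sulfur would keep or shift the number stays open.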